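The source may report more compounds than this note shows. Statements on the series, on what has been measured and on what is new or still open speak of the compounds shown alone.

Compound 1 `CC(=O)OC1C(CCl)OC(n2c(Cl)nc3cc(Cl)c(Cl)cc32)C1OC(C)=O` and compound 2 `CC(=O)OC1C(CBr)OC(n2c(Cl)nc3cc(Cl)c(Cl)cc32)C1OC(C)=O` share one core and differ in a single spot, while compound 3 `O[C@@H]1[C@@H](CCl)OC(n2c(Cl)nc3cc(Cl)c(Cl)cc32)[C@@H]1O` carries a second core; the difference between the two cores is not broken down here. In a functional assay on HFF cells (Homo sapiens) for cytotoxicity (on this read-out higher numbers stand for weaker inhibition and lower numbers for stronger inhibition), compound 1 gives 32000 nM. In this assay compound 2 gives 32000 nM, and the step of no change at the digits printed from compound 1 to compound 2 (within the scatter) is made by the change (bromo in place of chloro on a saturated chain carbon bound to a saturated ring carbon). In this assay compound 3 gives 32000 nM, level with compound 1 and with compound 2 within the scatter. No compound among these three can be called stronger or weaker than another.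

Compound 4 `O[C@@H]1[C@@H](CBr)OC(n2c(Cl)nc3cc(Cl)c(Cl)cc32)[C@@H]1O` is not yet measured. Among the measured compounds shown here, it stands to compound 3 as compound 2 stands to compound 1: the change bromo in place of chloro on a saturated chain carbon bound to a saturated ring carbon is the same change, on the same kind of carbon, as the one that carried compound 1 to compound 2. That earlier change left the reading unmoved, and the free-diol core of compound 3 sits at the same level as both acetylated compounds, so the same flat outcome is expected on this core. For the measured compounds named here, compound 4 is expected to show a step of no change at the digits printed from compound 3 to compound 4 (within the scatter) in this assay, because the single measured instance of this change gave no change at the digits printed from compound 1 to compound 2 (within the scatter). The estimate for compound 4 in this assay is therefore 32000 nM, expected to lie between 16000 nM and 64000 nM.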

Compound 4, half-maximal inhibitory concentration: 32000 nM
The estimate for compound 4 equals the measured number at the digits printed; the range from low to high includes it.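

In this assay, the exchange of chloromethyl for bromomethyl on the second core gives no change at the digits printed from compound 3 to compound 4 (within the scatter). Set beside the same exchange on the first core, the result carries over from one core to the other without a measurable difference: the same change on two cores in this assay, no change at the digits printed (within the scatter) from compound 1 to compound 2 and no change at the digits printed (within the scatter) from compound 3 to compound 4, 1.0-fold (0.00 log units) apart, within the scatter of two such steps. Among the compounds shown here, this shows that the exchange left the reading flat on both cores, but it rests on only two pairs of compounds whose four readings all stand level, so it does not show that the result would hold on a further core, or on a core where the starting reading lies elsewhere, and it offers no explanation for the flat result.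

The compounds shown leave open whether any group other than chloro or bromo on that saturated chain carbon, such as iodo, an amine, a carboxylic acid or a longer chain, would shift the reading in this assay at all. They also leave open whether the chloro groups on the rest of the shared framework have any bearing on the reading, since these stay the same in all four compounds.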